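The source may hold more compounds than are shown below. What is called first, only, known or untested is meant among the compounds shown, and "the series" means these compounds.

In a functional assay on DU-145 cells (Homo sapiens) for inhibition, read by trypan blue exclusion, with a stated time of 96 h (a higher number here means a weaker inhibitor of growth, a lower number a stronger inhibitor of growth), compound 3 `Cc1ccc(S/C(=C/c2cc(Cl)cc(Cl)c2Cl)C(=O)c2ccc(Cl)cc2)cc1` gives 50000 nM. Compound 1 `Cc1ccsc1/C=C(/SCc1ccc(Cl)c(Cl)c1)C(=O)c1ccc(Cl)cc1` gives 50000 nM, level with it at the digits shown. Compound 2 `Cc1ccc(S/C(=C/c2ccc(N(C)C)cc2)C(=O)c2ccc(Cl)cc2)cc1` returns only a limit of the assay, > 100000 nM, and not a number. Compound 4 `Cc1ccc(S/C(=C/c2sccc2C)C(=O)c2ccc(Cl)cc2)cc1` has not yet been measured. It differs from compound 3 as follows: 3-methylthiophen-2-yl in place of 2,3,5-trichlorophenyl on a double-bonded chain carbon bound to a double-bonded chain carbon. In short, 3-methylthiophen-2-yl stands in place of 2,3,5-trichlorophenyl on a double-bonded chain carbon bound to a double-bonded chain carbon.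

One measured step changes the group at this same place: an at least 2.0-fold lower number from compound 2 to compound 3 (0.30 log units; that floor lies within the scatter). That step starts from a limit, so it gives a floor and not a true size, and this floor stays within the scatter. It offers no firm ground for expecting a large move in either direction. The entering group also appears in compound 1, which gives 50000 nM, and this is the best numerical guide available. No change beyond the scatter is therefore expected in this assay, and the estimate means no change at the digits printed from compound 3 to compound 4 (within the scatter). A reading at the limit of the assay remains possible. For compound 4 the expected value is 50000 nM, with an estimated range of 15000 nM to 100000 nM.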

Compound 4, concentration for 50% growth inhibition: 50000 nM
Compound 4: middle estimate and measured number agree at the digits printed; measured number inside the range.
By their numbers in this assay, from the lowest: compounds 1, 3 and 4 (each within the scatter of the next). At a limit, above all of these: compound 2.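

In this assay, among the compounds shown here, the earlier compounds offered only a floor at this place, whereas no change at the digits printed from compound 3 to compound 4 (within the scatter) is a step with a number at both ends, and it holds although the group shrinks from 9 heavy atoms with 3 chlorine to 6 heavy atoms with 1 sulfur. The other place, on the sulfur, can now be read with 3-methylthiophen-2-yl held fixed: no change at the digits printed from compound 1 to compound 4 (within the scatter), so 4-methylphenyl and 3,4-dichlorobenzyl cannot be told apart in this pair. The remaining step starts from a limit of the assay and not a number, so an at least 2.0-fold lower number from compound 2 to compound 4 (0.30 log units; that floor lies within the scatter) is only a floor: the limit of > 100000 nM in this assay, at which 1 of the 4 values shown sits.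

The compounds shown leave open whether any group on a double-bonded chain carbon bound to a double-bonded chain carbon can lower the number beyond the scatter, as the three compounds with true numbers all read alike. A saturated ring such as cyclohexyl or a carboxylic acid at that place, or a longer chain on the sulfur, would test how far this flat reading extends.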